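The source may hold more compounds than are shown below. What is called first, only, known or untested is meant among the compounds shown, and "the series" means these compounds.

Compound 1 `CCc1nc2c(-c3ccc(Cl)cc3C(F)(F)F)nccc2n1C(CC)C1CC1`: 4.4 nM
Compound 2 `CCC[C@@H](C)n1c(CC)nc2c(-c3ccc(OC(F)(F)F)cc3Cl)nccc21`: 1.9 nM
Compound 3 `CCc1nc2c(-c3ccc(C(F)(F)F)cc3Cl)nccc2n1C(CC)CC`: 5.4 nM

All three were measured in an assay for binding affinity to Corticotropin releasing factor receptor (Rattus norvegicus); a lower number here means a stronger inhibitor, a higher number a weaker inhibitor. Compound 1 has the second highest of the three numbers. Its nearest neighbour is compound 3, and those two values lie within the scatter of each other. Compound 2 has a lower number, and that gap lies beyond the scatter. Compound 4 `CCc1nc2c(-c3ccc(Cl)cc3C)nccc2n1C(CC)C1CC1` has not yet been measured. It differs from compound 1 by methyl in place of trifluoromethyl on an aromatic carbon. For the measured compounds named here, no measured pair shows this same change, so the expectation rests on the change alone. A small step is expected, toward a somewhat higher number, though it may well stay within the scatter. Compound 4 is estimated at 7 nM, with a range from 2.5 nM to 20 nM. This corresponds to an expected step of a 1.6-fold higher number from compound 1 to compound 4 (0.20 log units; within the scatter).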

Compound 4, inhibition constant: 14 nM
The estimate for compound 4 lay 2.0-fold (0.30 log units) below the measured number; the range from low to high includes it.
By their numbers in this assay, from the lowest: compound 2; then compounds 1 and 3 (each within the scatter of the next); then compound 4.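

Swapping trifluoromethyl for methyl gives a 3.2-fold higher number from compound 1 to compound 4 (0.50 log units; beyond the scatter) in this assay, so this aromatic carbon, ortho to a large group, is not indifferent to the group it carries. For the compounds shown here, this is the first pair here that differs in one place, and its step lies beyond the scatter. Nothing available explains the shift.

Going by these compounds, it remains open how a methoxy group or a nitrile at this place would compare with trifluoromethyl and methyl. On these data alone, it is also open whether the same swap would give a similar step in compounds with a different chain on the shared core.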